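Chain extension on the amino substituent of the shared core

A few compounds are considered here, and "the series" means these few. Any claim that something is new, unique, unknown or untested is made for them only; others in the source may bear on it.

Compound 2 `CCNc1nc2c(SCc3ccccc3)ncnc2n1C1O[C@H](CO)[C@@H](O)[C@H]1O` gives 9.5 nM in an assay on cell membranes for binding affinity to Equilibrative nucleoside transporter 1 (Homo sapiens) (a higher number here means a weaker inhibitor, a lower number a stronger inhibitor), and holds the lowest of the two numbers measured; compound 1 `CNc1nc2c(SCc3ccccc3)ncnc2n1C1O[C@H](CO)[C@@H](O)[C@H]1O` gives 28 nM in this assay. Compound 3 `CCCNc1nc2c(SCc3ccccc3)ncnc2n1C1O[C@H](CO)[C@@H](O)[C@H]1O` differs from compound 2 by methyl in place of hydrogen on a saturated chain carbon, two bonds along the chain from a nitrogen on an aromatic ring; read one bond further out, this is ethyl to propyl, or ethylamino to propylamino. Among the compounds with values here, only one measured step bears on the change, and it is the same kind of addition one carbon closer to the ring nitrogen: the number fell because a 2.9-fold lower number from compound 1 to compound 2 (0.47 log units; beyond the scatter) was modest but beyond the scatter. The present step lies further from the ring, so a smaller gain, or no change beyond the scatter, is expected in this assay for compound 3, estimated as a 1.6-fold lower number from compound 2 to compound 3 (0.20 log units; within the scatter). Compound 3 is therefore expected at 6 nM, with a range of 2.5 nM to 15 nM.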

Compound 3, inhibition constant: 5.3 nM
The estimate for compound 3 lay 1.1-fold (0.05 log units) above the measured number, within the range that was stated.
By their numbers in this assay, from the lowest: compounds 3 and 2 (each within the scatter of the next); then compound 1.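

In this assay, the ethyl to propyl change, two bonds along the chain from a nitrogen on an aromatic ring, gives a 1.8-fold lower number from compound 2 to compound 3 (0.25 log units; within the scatter) and so cannot be told apart from no change. Within the data shown here, the first added carbon therefore remains the only single-carbon step beyond the scatter, while ethyl in place of hydrogen on the saturated chain carbon bound to that nitrogen gives a 5.3-fold lower number from compound 1 to compound 3 (0.72 log units; beyond the scatter) over the two additions together. No measurement here gives a reason for this pattern.

Going by these compounds, whether the numbers stay level with butyl or a longer chain remains open, as does the reading for a branched chain such as isopropyl, a cyclopropyl ring, or a chain ending in an amine or a carboxylic acid. On these data alone, all three compounds share one core, so whether these steps hold on another core is also open.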